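Swapping Bromo for Methoxy on a Shared Core

The compounds below may be only part of what the source reports. "The series", "measured", "known", "first", "only" and "open" are said of these compounds alone.

Measured so far:
- compound 1 `COc1ccc2[nH]c(-c3cn(-c4ccccc4)nc3-c3ccccc3)nc2c1`: 2870 nM
- compound 2 `Fc1ccc(-c2nn(-c3ccccc3)cc2-c2nc3cc(Br)ccc3[nH]2)cc1`: 4940 nM

In a functional assay on HeLa cells (Homo sapiens) for antiproliferative activity, read by MTT assay, with a stated time of 48 h (on this read-out lower numbers stand for stronger inhibition and higher numbers for weaker inhibition), compound 2 gives 4940 nM, and compound 1 gives 2870 nM. These two numbers lie within the usual scatter of each other, so neither compound can be ranked above the other.

The next compound to be tested is compound 3 `COc1ccc2[nH]c(-c3cn(-c4ccccc4)nc3-c3ccc(F)cc3)nc2c1`. It differs from compound 2 in one place, with methoxy in place of bromo on an aromatic carbon.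

Going by the values given here, no measured pair here shows this swap on its own, so the expectation rests on little. Among the compounds with values here, the one clue is that compound 1 also carries methoxy and gives 2870 nM. In this assay the expected change is small and slightly toward a lower number, a 1.5-fold lower number from compound 2 to compound 3 (0.19 log units; within the scatter), which is not expected to go beyond the scatter.

For compound 3 the estimated value is 3200 nM, with an expected range from 1300 nM to 7500 nM.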

Compound 3, half-maximal inhibitory concentration: 7510 nM
Estimate against measurement, compound 3: 2.3-fold (0.37 log units) below, outside the stated range (above it).
By their numbers in this assay, from the lowest: compounds 1, 2 and 3 (each within the scatter of the next, the first and the last beyond it).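

In this assay, putting methoxy in place of bromo on the shared core gives a 1.5-fold higher number from compound 2 to compound 3 (0.18 log units; within the scatter), so with fluoro held in place, these two groups cannot be told apart at this position. Going by these compounds alone, compound 3 also forms a one-place pair with compound 1, and here fluoro in place of hydrogen on an aromatic carbon, with methoxy held fixed, gives a 2.6-fold higher number from compound 1 to compound 3 (0.42 log units; beyond the scatter) as a modest loss of activity that goes beyond the usual scatter, making it the only step so far that can be read as a real difference. Nothing available explains either step.

On these data alone, whether fluoro costs a similar amount of activity when bromo replaces methoxy stays open, as does whether the two groups would still match with hydrogen in place of that fluoro. Also open, as far as these compounds go, is how a quite different group at the bromo and methoxy position, such as an amine, a carboxylic acid or a longer chain, would behave on this core.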